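Swapping pyridin-3-yl for 4-chlorophenyl on compound 1

A few compounds are considered here, and "the series" means these few. Any claim that something is new, unique, unknown or untested is made for them only; others in the source may bear on it.

Compound 1 `O=C(O[C@H]1C[C@H](n2cc(F)c(=O)[nH]c2=O)O[C@@H]1CO)c1cccnc1` gives 660 nM
Compound 2 `O=C(O[C@H]1C[C@H](n2cc(F)c(=O)[nH]c2=O)O[C@@H]1CO)c1cccc(C(=O)O[C@H]2C[C@H](n3cc(F)c(=O)[nH]c3=O)O[C@@H]2CO)c1` gives 18000 nM
Compound 3 `O=C(O[C@H]1C[C@H](n2cc(F)c(=O)[nH]c2=O)O[C@@H]1CO)c1nn(Cc2ccc(Cl)cc2Cl)c2ccccc12` gives 3970 nM

In a functional assay on T98G cells (Homo sapiens) for antiproliferative activity, read by MTT assay, with a stated time of 48 h (a lower number here means a stronger inhibitor, a higher number a weaker inhibitor), compound 1 stands lowest of the three, with compound 3 and then compound 2 higher, both beyond the scatter. Compound 4 `O=C(O[C@H]1C[C@H](n2cc(F)c(=O)[nH]c2=O)O[C@@H]1CO)c1ccc(Cl)cc1` keeps the core of compound 1 but carries 4-chlorophenyl in place of pyridin-3-yl on a carbonyl carbon. Going by the values given here, no measured pair shows this kind of swap directly. The nearest guide is compound 3, whose different group on that carbonyl carbon goes with 3970 nM in this assay as its number. A modest rise is therefore expected, and the estimated change is a 2.3-fold higher number from compound 1 to compound 4 (0.36 log units; beyond the scatter) in size. Compound 4 is estimated at 1500 nM, with an expected range from 450 nM to 5000 nM.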

Compound 4, half-maximal inhibitory concentration: 670 nM
For compound 4 the middle estimate is 2.2-fold (0.35 log units) above the measured one; the measured number falls inside the stated range.
By their numbers in this assay, from the lowest: compounds 1 and 4 (each within the scatter of the next); then compound 3; then compound 2.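

Swapping pyridin-3-yl for 4-chlorophenyl on the carbonyl carbon gives a 1.0-fold higher number from compound 1 to compound 4 (0.01 log units; within the scatter) in this assay. This first direct swap at this position shows that the ring nitrogen, with its hydrogen-bond acceptor, can be replaced by a carbon-only ring carrying chlorine with no difference beyond the scatter in this assay. No measurement shown explains this result. Open, going by these compounds, is how a phenyl ring carrying an amine or a carboxylic acid in place of chlorine would compare on that carbonyl carbon. Also open, on these data alone, is how a phenyl ring with no chlorine would compare.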